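Working notes on compounds 1 to 4 of the series

The source may report more compounds than this note shows. Statements on the series, on what has been measured and on what is new or still open speak of the compounds shown alone.

Measured so far:
compound 1 `Cn1c(-c2ccc(NC(=O)CSc3nc4ccccc4o3)cc2)nc(-c2ccccc2)c1-c1ccccc1`, 27.4%
compound 2 `Cn1c(-c2ccc(NC(=O)CSc3nc4cc(Cl)ccc4o3)cc2)nc(-c2ccccc2)c1-c1ccccc1`, 2.5%
compound 3 `Cc1ccc2oc(SCC(=O)Nc3ccc(-c4nc(-c5ccccc5)c(-c5ccccc5)n4C)cc3)nc2c1`, 1.9%

In a functional assay on MCF7 cells (Homo sapiens) for cytotoxicity, read by MTT assay, with a stated time of 24 h, tested at 1.6 ug/mL (a lower number here means a weaker effect, a higher number a stronger effect of the compound at the concentration tested), compound 3 gives 1.9%, the lowest of the three numbers; compound 2 lies within the scatter of it, while compound 1 is separated from it by a number 25.5 percentage points lower from compound 1 to compound 3 (beyond the scatter). Compound 4 `Cn1cnnc1SCC(=O)Nc1ccc(-c2nc(-c3ccccc3)c(-c3ccccc3)n2C)cc1` differs from compound 3 in one place: 4-methyl-4H-1,2,4-triazol-3-yl in place of 5-methyl-1,3-benzoxazol-2-yl on a sulfur. Neither measured step bears directly on this change; a number 24.9 percentage points lower from compound 1 to compound 2 (beyond the scatter) and a number 0.6 percentage points lower from compound 2 to compound 3 (within the scatter) concern only substituents on the 5-methyl-1,3-benzoxazol-2-yl group that now leaves, so they give no direction for exchanging it against 4-methyl-4H-1,2,4-triazol-3-yl. Compound 3 sits near the floor of this assay, so a step down beyond the scatter is hardly possible, and the expected step is a number 6.1 percentage points higher from compound 3 to compound 4 (within the scatter), not beyond the scatter. Compound 4 is therefore estimated at 8%, between 0% and 30%.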

Compound 4, a percentage reported as activity, at one concentration (the size of the read-out at that concentration, not a potency): 42.8%
Compound 4: the middle estimate sits 34.8 percentage points below what was measured, outside the stated range (above it).
By their numbers in this assay, from the lowest: compounds 3 and 2 (each within the scatter of the next); then compound 1; then compound 4.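

Replacing the group on the sulfur is the only change shown that raises the number in this assay (a number 40.9 percentage points higher from compound 3 to compound 4 (beyond the scatter)) (a number 40.3 percentage points higher from compound 2 to compound 4 (beyond the scatter)) (a number 15.4 percentage points higher from compound 1 to compound 4 (beyond the scatter)). This position therefore accepts 4-methyl-4H-1,2,4-triazol-3-yl, a single five-membered aromatic ring, in place of each 1,3-benzoxazol-2-yl group, and the read-out rises with the change. No measurement offered here accounts for the rise.

Which feature of 4-methyl-4H-1,2,4-triazol-3-yl carries the gain remains open. Also open, going by these compounds, is how an amine, a carboxylic acid or a longer chain on the sulfur would compare.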